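Two Hydroxyls in Place of a Chloro on a Shared Core

The source may report more compounds than this note shows. Statements on the series, on what has been measured and on what is new or still open speak of the compounds shown alone.

compound 1, `COc1cc(-c2cc(-c3ccc(Cl)cc3)nc(-c3ccccc3)n2)cc(OC)c1OC`: 7980 nM
compound 2, `COc1cc(-c2cc(-c3ccccc3)nc(-c3ccccc3)n2)cc(OC)c1OC`: 9950 nM

Of the compounds shown here, two have been measured in a functional assay on HCT-116 cells (Homo sapiens) for inhibition, read by MTT assay, with a stated time of 48 h; on this read-out lower numbers stand for stronger inhibition and higher numbers for weaker inhibition. Within the data shown here, compound 1 has the lower of the two numbers, but its only neighbour differs from it by a 1.2-fold higher number from compound 1 to compound 2 (0.10 log units; within the scatter), a step that stays within the usual scatter, so the two measured compounds cannot be told apart on this read-out.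

The unmeasured compound 3, `COc1cc(-c2cc(-c3ccc(O)cc3O)nc(-c3ccccc3)n2)cc(OC)c1OC`, differs from compound 1 by 2,4-dihydroxyphenyl in place of 4-chlorophenyl on an aromatic carbon.

Among the measured compounds shown here, the one measured step, a 1.2-fold higher number from compound 1 to compound 2 (0.10 log units; within the scatter), removed the chloro group and left the number essentially unchanged. For the measured compounds named here, no measured pair introduces a hydroxyl group or any other group onto that phenyl ring, so nothing among the measured compounds speaks to the entering 2,4-dihydroxyphenyl. On this basis no step beyond the scatter can be predicted in either direction, and the uncertainty is wide.

Compound 3 is therefore expected to give about 8500 nM, with a range from 2500 nM to 30000 nM. The expected step is a 1.1-fold higher number from compound 1 to compound 3 (0.03 log units; within the scatter), which the measurement will now settle.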

Compound 3, half-maximal inhibitory concentration: 5890 nM
The estimate for compound 3 lay 1.4-fold (0.16 log units) above the measured number, and the stated range covers the measured number.
By their numbers in this assay, from the lowest: compounds 3, 1 and 2 (each within the scatter of the next).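

In this assay the step of a 1.4-fold lower number from compound 1 to compound 3 (0.13 log units; within the scatter) comes with 2,4-dihydroxyphenyl in place of 4-chlorophenyl on this aromatic carbon, and the step of a 1.7-fold lower number from compound 2 to compound 3 (0.23 log units; within the scatter) comes with the same group in place of phenyl. Among these compounds, the earlier pair showed only that losing the chloro group leaves the read-out within the scatter, whereas these steps show that a ring carrying two hydroxyl groups, with 2 hydrogen-bond donors and 2 hydrogen-bond acceptors where 4-chlorophenyl has none, also stays within it at this position. Compounds 1, 2 and 3 therefore cannot be told apart on this read-out, and nothing beyond these numbers bears on the result, so it remains a plain observation without an explanation.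

The compounds shown leave open whether a single hydroxyl group on this ring would behave as the two do, and whether an amine or a carboxylic acid there would move the number beyond the scatter. They also leave open whether any change at this position can give a clear step at all, or whether other parts of the shared core must change for that.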